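Swapping Fluoro for Chloro on Compound 1

This account rests on a few compounds, and the source may have more. Where it says the series, first, only, none or still open, it means among the compounds named here.

In a toxicity assay on cells (Macrophage, Mus musculus, strain BALB/c) for cytotoxicity, read by MTT assay (a higher number here means a weaker inhibitor, a lower number a stronger inhibitor), compound 1 (`C=CCOc1cc(OC)c(C(=O)/C=C/c2ccc(F)cc2)c(OCC=C)c1`) gives 13800 nM and compound 2 (`C=CCOc1cc(OC)c(C(=O)/C=C/c2cc(OC)c(OC)c(OC)c2)c(OCC=C)c1`) gives 12000 nM. These two numbers lie within the usual scatter of each other, so compound 1 stands level with compound 2 and the pair cannot be ranked. Compound 3 (`C=CCOc1cc(OC)c(C(=O)/C=C/c2ccc(Cl)cc2)c(OCC=C)c1`) has not yet been measured. It departs from compound 1 by chloro in place of fluoro on an aromatic carbon, with chloro in place of fluoro on an aromatic carbon, para to a large group. Among the compounds with values here, no measured pair isolates this change, so the data give no direct guide to its size. The expectation rests only on compound 1 at 13800 nM and compound 2 at 12000 nM, and no shift beyond the scatter is expected in this assay. The estimated change, a 1.2-fold lower number from compound 1 to compound 3 (0.06 log units; within the scatter), is therefore small. For compound 3 the expected value is 12000 nM, within an estimated range of 6500 nM to 21000 nM.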

Compound 3, half-maximal inhibitory concentration: 13000 nM
The estimate for compound 3 lay 1.1-fold (0.03 log units) below the measured number; low and high end bracket the measured number.
By their numbers in this assay, from the lowest: compounds 2, 3 and 1 (each within the scatter of the next).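

In this assay, within the data shown here, the exchange of fluoro for chloro on an aromatic carbon, para to a large group, gives a 1.1-fold lower number from compound 1 to compound 3 (0.03 log units; within the scatter) and so provides the first pair that differs in only one place. The 4-fluorophenyl and 4-chlorophenyl forms therefore cannot be ranked, and this halogen exchange produces no change that can be told apart from the scatter. Nothing available offers an explanation for this result.

The compounds shown leave open whether an amine, a carboxylic acid or a longer chain such as butyl at this position would shift the number beyond the scatter in this assay at all. They also leave open whether bromo would read like fluoro and chloro here.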